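The compounds below may be only part of what the source reports. "The series", "measured", "known", "first", "only" and "open" are said of these compounds alone.

In an ADME assay on cells (Homo sapiens) for activation (a lower number here means that less compound is tolerated, a higher number that more compound is tolerated), compound 1 `COc1ccc2c(OCC[C@@H]3NC(=O)N(C)CCCC/C=C\[C@@H]4C[C@@]4(C(=O)NS(=O)(=O)C4(C)CC4)NC3=O)cc(-c3nc(C(C)C)cs3)nc2c1` gives 6500 nM, compound 2 `COc1ccc2c(OCC[C@@H]3NC(=O)N(C)CCCC/C=C\[C@@H]4C[C@@]4(C(=O)NS(=O)(=O)C4(C)CC4)NC3=O)cc(-c3nc(C(C)C)cs3)nc2c1Br` gives 28300 nM and compound 3 `COc1ccc2c(OCC[C@@H]3NC(=O)N(C)CCCC/C=C\[C@@H]4C[C@@]4(C(=O)NS(=O)(=O)C4(C)CC4)NC3=O)cc(-c3nc(C(C)C)cs3)nc2c1Cl` gives 37400 nM. Compound 3 therefore sits level with compound 2 at the top of the three, with a 1.3-fold higher number from compound 2 to compound 3 (0.12 log units; within the scatter), and clear of compound 1. Compound 4 `COc1ccc2c(OCC[C@@H]3NC(=O)N(C)CCCC/C=C\[C@@H]4C[C@@]4(C(=O)NS(=O)(=O)N4CCOCC4)NC3=O)cc(-c3nc(C(C)C)cs3)nc2c1Cl` differs from compound 3 in one group: morpholin-4-yl in place of 1-methylcyclopropyl on a sulfonyl sulfur. The measured steps, a 4.4-fold higher number from compound 1 to compound 2 (0.64 log units; beyond the scatter) and a 5.8-fold higher number from compound 1 to compound 3 (0.76 log units; beyond the scatter), were modest, but both are swaps on an aromatic carbon, so none of them tests this sulfonyl group. With no measured guide to direction, no step beyond the scatter is expected in this assay. The estimated step is a 1.2-fold lower number from compound 3 to compound 4 (0.10 log units; within the scatter). For compound 4 the estimated value is 30000 nM, with a range of 11000 nM to 80000 nM.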

Compound 4, half-maximal cytotoxic concentration: 26400 nM
Compound 4: middle estimate off by 1.1-fold (0.06 log units), on the high side; the range from low to high includes it.
By their numbers in this assay, from the lowest: compound 1; then compounds 4, 2 and 3 (each within the scatter of the next).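

In this assay, the first change shown on the sulfonyl sulfur, morpholin-4-yl in place of 1-methylcyclopropyl, gives a 1.4-fold lower number from compound 3 to compound 4 (0.15 log units; within the scatter). In this one pair, then, a six-membered ring with two hetero atoms replaces a three-membered carbon ring on this sulfur with no shift beyond the scatter. Nothing here explains this result.

Open, going by these compounds, is whether a dimethylamino group or a piperazine on this sulfur would behave the same way. Also open, on these data alone, is whether this swap gives the same result with hydrogen, as in compound 1, or bromo, as in compound 2, in place of the chloro.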